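Hydroxymethyl for carboxy on the pyrrolidine of compound 3

The source may report more compounds than this note shows. Statements on the series, on what has been measured and on what is new or still open speak of the compounds shown alone.

Compound 3 `Cc1nn([C@H](C)c2ccc(Cl)cc2Cl)c2nc(N3CC[C@H](N4CCC[C@H]4C(=O)O)[C@H](C)C3)cnc12` gives 670 nM in a functional assay on cells for antagonist activity at C-C chemokine receptor type 4 (Homo sapiens), read by fluorescence and calcium flux, with stated times of 2.5 s and 45 s (a lower number here means a stronger inhibitor, a higher number a weaker inhibitor), the highest number among the three measured compounds. Compound 1 `Cc1nn([C@H](C)c2ccc(Cl)cc2Cl)c2nc(N3CC[C@H](N4CCC4)[C@H](C)C3)cnc12` gives 58 nM and compound 2 `Cc1nn([C@H](C)c2ccc(Cl)cc2Cl)c2nc(N3CC[C@H](N4CCCCC4)[C@H](C)C3)cnc12` gives 42 nM in this assay; the step of a 1.4-fold lower number from compound 1 to compound 2 (0.14 log units; within the scatter) lies within the scatter, while a 12-fold higher number from compound 1 to compound 3 (1.06 log units; beyond the scatter) and a 16-fold higher number from compound 2 to compound 3 (1.20 log units; beyond the scatter) are both large. Compound 4 `Cc1nn([C@H](C)c2ccc(Cl)cc2Cl)c2nc(N3CC[C@H](N4CCC[C@H]4CO)[C@H](C)C3)cnc12` differs from compound 3 by one change: hydroxymethyl in place of carboxy on a saturated ring carbon. For the measured compounds named here, no measured pair shows exactly this change. The two large steps into compound 3 show that the carboxypyrrolidinyl group carries a markedly higher number than the unsubstituted azetidinyl or piperidinyl rings, and compound 4 keeps the pyrrolidine but not the carboxy group, so part of that difference is expected to be recovered in this assay. Compound 4 is therefore expected to give 150 nM, with a range from 40 nM to 500 nM. That expectation means a step of a 4.5-fold lower number from compound 3 to compound 4 (0.65 log units; beyond the scatter) toward a lower number. The number expected for compound 4 still lies somewhat above those measured for compound 1 and compound 2.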

Compound 4, half-maximal inhibitory concentration: 32 nM
The estimate for compound 4 lay 4.7-fold (0.67 log units) above the measured number; the whole stated range lies above it.
By their numbers in this assay, from the lowest: compounds 4, 2 and 1 (each within the scatter of the next); then compound 3.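

In this assay the swap of carboxy for hydroxymethyl on the saturated ring carbon gives a 21-fold lower number from compound 3 to compound 4 (1.32 log units; beyond the scatter) and so ties the high number of compound 3 to the carboxy group and not to the pyrrolidine ring, which compound 4 keeps. With the 2-(hydroxymethyl)pyrrolidin-1-yl group, the comparisons with the unsubstituted rings give a 1.3-fold lower number from compound 2 to compound 4 (0.12 log units; within the scatter) and a 1.8-fold lower number from compound 1 to compound 4 (0.26 log units; within the scatter) and so show that this position can carry a substituted five-membered ring with no difference beyond the scatter from the azetidin-1-yl or piperidin-1-yl compounds. No measurement offered here accounts for the result with the carboxy group.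

Still open, from the compounds shown here alone, is whether an unsubstituted pyrrolidine would match compound 4. Also open, going by these compounds, is whether a methoxymethyl group, an aminomethyl group or a longer hydroxyethyl chain on the same ring carbon would give a similar number.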